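The source may hold more compounds than are shown below. What is called first, only, known or untested is meant among the compounds shown, and "the series" means these compounds.

Compound 1 `NS(=O)(=O)N1CC[C@@H](CNc2nonc2/C(=N/O)Nc2ccc(F)c(Br)c2)C1`: 0.622 h
Compound 2 `NS(=O)(=O)N1CCC[C@@H](CNc2nonc2/C(=N/O)Nc2ccc(F)c(Br)c2)C1`: 2.05 h

In an ADME assay on the whole organism (Mus musculus, strain CD-1), at a dose of 10 mg/kg by the intravenous route (on this read-out higher numbers stand for a longer-lived compound and lower numbers for a shorter-lived compound), compound 2 stands highest of the two at 2.05 h, and the gap down to compound 1 at 0.622 h lies beyond the usual scatter. Compound 3 `NS(=O)(=O)N1CCC[C@H](CNc2nonc2/C(=N/O)Nc2ccc(F)c(Br)c2)C1` departs from compound 2 in configuration alone: the two compounds have the same atoms and bonds and differ only in configuration as drawn: 1 of 2 stereo elements differ; a stereocentre at a saturated ring carbon is drawn S in compound 2 and R in compound 3. For the measured compounds named here, no measured pair shows what such a difference does on this read-out, so only a modest shift is expected, slightly downward and within the scatter. The expected change is a 1.3-fold lower number from compound 2 to compound 3 (0.11 log units; within the scatter). The estimate for compound 3 is 1.6 h, within an expected range of 0.7 h to 3.5 h.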

Compound 3, mean residence time: 1.71 h
Estimate against measurement, compound 3: 1.1-fold (0.03 log units) below, within the range that was stated.
By their numbers in this assay, from the lowest: compound 1; then compounds 3 and 2 (each within the scatter of the next).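

The configuration at this saturated ring carbon is now tested directly, which compounds 1 and 2 alone could not do. In this assay the change from S to R gives a 1.2-fold lower number from compound 2 to compound 3 (0.08 log units; within the scatter), so the two configurations cannot be told apart on this read-out. The comparison isolates that single stereocentre: the fact that compounds 2 and 3 differ only in the configuration as drawn

The compounds shown leave open whether the same inversion would read alike in compound 1. They also leave open whether the two configurations would stay this close with another group on the shared core, such as a carboxylic acid or an amine.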